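Biaryl end replacement in the cyclopropane carboxamide series

A few compounds are considered here, and "the series" means these few. Any claim that something is new, unique, unknown or untested is made for them only; others in the source may bear on it.

Two compounds of the series have been run in a functional assay for agonist activity at G protein-coupled receptor 88 (Homo sapiens), read by HTRF and cAMP accumulation; on this read-out higher numbers stand for an effect only at larger amounts of compound and lower numbers for an effect already at smaller amounts. Compound 1 `CC[C@H](C)[C@H](N)CN(C(=O)[C@@H]1C[C@H]1c1cc(F)cc(F)c1)c1ccc(-c2ccccc2)cc1` gives 960 nM in this assay. Compound 2 `CC(C)C[C@H](N)CN(C(=O)[C@@H]1C[C@H]1c1ccccc1)c1ccc(-c2cccnc2)cc1` gives 10000 nM, the highest of the two numbers, and its nearest neighbour, compound 1, stands a long way off, beyond the scatter. The two compounds differ in several places at once, so no single change can be tied to that gap.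

Compound 3 `CC(C)C[C@H](N)CN(C(=O)[C@@H]1C[C@H]1c1ccccc1)c1ccc(-c2ccccc2Cl)cc1` has not yet been measured. It keeps the core of compound 2 and differs from it in one place: 2-chlorophenyl in place of pyridin-3-yl on an aromatic carbon. Within the data shown here, no measured pair isolates this exchange, so the step cannot be read off from the data; compound 1, with its lower number, differs from compound 2 in other places as well. Because compound 2 sits at 10000 nM, the top of the small set, the exchange of pyridin-3-yl for 2-chlorophenyl is expected to bring the number down somewhat, with a wide margin of doubt. The step of a 3.3-fold lower number from compound 2 to compound 3 (0.52 log units; beyond the scatter) is the estimated outcome. Compound 3 is thus expected to give 3000 nM, with a range of 700 nM to 13000 nM.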

Compound 3, half-maximal effective concentration: 3800 nM
Beside the measured number, compound 3's estimate is 1.3-fold (0.10 log units) below it; the range from low to high includes it.
By their numbers in this assay, from the lowest: compound 1; then compound 3; then compound 2.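

In this assay, among these compounds, the biaryl end gives the first single-place reading: 2-chlorophenyl in place of pyridin-3-yl, on an aromatic carbon para to a large group, produces a 2.6-fold lower number from compound 2 to compound 3 (0.42 log units; beyond the scatter), a modest step but one beyond the scatter. The number at this position therefore depends on which aromatic ring is attached, something the earlier pair could not show, since compound 1 and compound 2 differ in several places at once. The exchange removes a ring nitrogen and the hydrogen-bond acceptor counted with it and adds a chlorine, but nothing available explains why the number moves.

The compounds shown leave open how the step divides between losing the ring nitrogen and gaining the chlorine, and an unsubstituted phenyl on the core of compound 2 would separate the two. Also open, on these data alone, is whether a methyl or a methoxy group in place of the chlorine would give a step of similar size, or whether the chlorine itself is needed.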